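A few compounds are considered here, and "the series" means these few. Any claim that something is new, unique, unknown or untested is made for them only; others in the source may bear on it.

The study measured three compounds in a toxicity assay on GES1 cells (Homo sapiens) for inhibition, read by CCK-8 assay, with a stated time of 72 h; a higher number here means a weaker inhibitor, a lower number a stronger inhibitor. Compound 1 `CC(C)(C)OC(=O)N1CCN(C(=O)Cn2cc(CN3C(=O)C(=O)c4c(Cl)ccc(Cl)c43)nn2)CC1` gives 84200 nM in this assay. Compound 2 `O=C1C(=O)N(Cc2cn(CC(=O)N3CCOCC3)nn2)c2c(Cl)ccc(Cl)c21` reaches only a limit of the assay, > 128000 nM, which is the limit of > 128000 nM in this assay, at which 1 of the 3 values shown sits. Compound 3 `O=C1C(=O)N(Cc2cn(CC(=O)N3CCNCC3)nn2)c2c(Cl)ccc(Cl)c21` is recorded as "nd(insoluble)" (no result reported) in this assay. Among the numbers shown, compound 2 therefore stands without a single value, as a limit only. Compound 4 `O=C1C(=O)N(Cc2cn(CC(=O)N3CCCCC3)nn2)c2c(Cl)ccc(Cl)c21` has not been measured; it differs from compound 2 by piperidin-1-yl in place of morpholin-4-yl on a carbonyl carbon. Among the measured compounds shown here, no step between measured compounds shows how this change acts, so compound 4 is expected to change little, with an expected step of an at least 1.0-fold lower number from compound 2 to compound 4 (0.02 log units; that floor lies within the scatter) within the scatter. Compound 4 is estimated at 120000 nM in this assay, between 50000 nM and 260000 nM, and a limit rather than a number remains likely.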

Compound 4, half-maximal inhibitory concentration: 50700 nM
For compound 4 the middle estimate is 2.4-fold (0.37 log units) above the measured one; measured number inside the range.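

In this assay, among the compounds shown here, the change gives an at least 2.5-fold lower number from compound 2 to compound 4 (0.40 log units; beyond the scatter), the first readable step at this position: the group on the carbonyl carbon can move the result beyond the scatter. The true size of the step stays open because compound 2 rests on a limit: the limit of > 128000 nM in this assay, at which 1 of the 4 values shown sits.

Steps involving compound 3 cannot be read, as it has no number. Going by these compounds, it remains open whether the oxygen that leaves or the ring as a whole drives the step, and how pyrrolidin-1-yl or an open-chain diethylamino group would read here.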